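Notes on compound 4: isopropyl in place of methoxy

The source may hold more compounds than are shown below. What is called first, only, known or untested is meant among the compounds shown, and "the series" means these compounds.

The set holds four structures. Compound 1 `O=C(O)c1cnc2cc(C(F)(F)F)ccc2c1`, compound 3 `COc1ccc2cc(C(=O)O)cnc2c1` and compound 2 `COc1cccc2c(=O)c(-c3nn[nH]n3)c[nH]c12` have been measured in a functional assay on the whole organism (strain Sprague-Dawley) for inhibition, with Rattus norvegicus as the target; a lower number here means that less compound is needed, a higher number that more compound is needed for the effect; compound 4 `CC(C)c1cccc2c(=O)c(-c3nn[nH]n3)c[nH]c12` has not. In this assay compound 1 gives only a limit, > 25 mg/kg. In this assay compound 3 likewise gives only a limit, > 25 mg/kg. For the measured compounds named here, the one recorded step, a step that the two limits leave unreadable from compound 1 to compound 3, is therefore unreadable because both of its ends sit at the limit of > 25 mg/kg in this assay, at which 2 of the 3 values shown sit. Going by the values given here, compound 2 gives 0.15 mg/kg in this assay, the single number among the three values shown.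

Compound 4 differs from compound 2 in one place: isopropyl in place of methoxy on an aromatic carbon. Among the compounds with values here, no measured step bears on this change. Within the data shown here, the only step recorded concerns methoxy in place of trifluoromethyl and has no readable size, so the series offers no guide to the effect of isopropyl in place of methoxy in this assay. The working expectation is therefore a step not beyond the usual scatter, a 2.0-fold higher number from compound 2 to compound 4 (0.30 log units; within the scatter), held with a wide range. Compound 4 is expected to give 0.3 mg/kg in this assay, the estimate running from 0.08 mg/kg to 1.2 mg/kg.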

Compound 4, minimum effective dose: 1.25 mg/kg
Compound 4: middle estimate off by 4.2-fold (0.62 log units), on the low side, and the stated range ends below it.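

In this assay, for the compounds shown here, isopropyl in place of methoxy on this aromatic carbon gives an 8.3-fold higher number from compound 2 to compound 4 (0.92 log units; beyond the scatter), the first step with a readable size. Going by these compounds alone, the only earlier step, from compound 1 to compound 3, cannot be read, since both of its ends are limits of the assay, so this pair is the first to show that the group on this carbon of the shared core changes the dose needed, with compound 4 still giving a number and not a limit. The change swaps a group of 2 heavy atoms with 1 hydrogen-bond acceptor for one of 3 carbon atoms with 0 hydrogen-bond acceptors, but no measured property in the series accounts for the step.

One pair cannot separate the loss of the oxygen from the gain in carbon, and a hydroxyl, an ethyl or an amine on this same carbon would be needed to tell these apart. Also open, on these data alone, is how a chlorine or a longer alkoxy chain would read on this carbon, and whether the step holds at any other place on the core of compound 2.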